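The source may hold more compounds than are shown below. What is called first, only, known or untested is meant among the compounds shown, and "the series" means these compounds.

Of the compounds shown here, two of one family have been tested in an assay on HEK293 cells for displacement of a labelled ligand from adenosine receptor A1 (Homo sapiens), read by scintillation counting, with a stated time of 60 min; on this read-out higher numbers stand for weaker inhibition and lower numbers for stronger inhibition. Compound 1 `N#Cc1sc(=S)n(-c2ccccc2)c1/N=C/c1ccc(Cl)cc1` gives 413 nM in this assay, and compound 2 `CCCn1c(/N=C/c2ccc(Br)cc2)c(C#N)sc1=S` gives 607 nM. These two numbers lie within the usual scatter of each other, so neither compound can be called the stronger binder on this evidence, and compound 2 simply sits alongside compound 1. Compound 3 `N#Cc1sc(=S)n(-c2ccccc2)c1/N=C/c1ccc(Br)cc1` has not been measured yet. It differs from compound 2 in one place: phenyl in place of propyl on an aromatic nitrogen, so that compound 3 carries the phenyl of compound 1 together with the bromine of compound 2. Compound 1 and compound 2 give numbers close together, and on that evidence the swap of propyl for phenyl on the aromatic nitrogen is expected to shift the number little, if at all, beyond the scatter. The expected step is a 1.3-fold lower number from compound 2 to compound 3 (0.13 log units; within the scatter). Compound 3 is therefore estimated at 450 nM, with a likely range from 200 nM to 1000 nM.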

Compound 3, inhibition constant: 186 nM
Beside the measured number, compound 3's estimate is 2.4-fold (0.38 log units) above it; measured number below the stated range.
By their numbers in this assay, from the lowest: compound 3; then compounds 1 and 2 (each within the scatter of the next).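

In this assay, the group on the aromatic nitrogen matters when the bromine stays in place: phenyl in place of propyl gives a 3.3-fold lower number from compound 2 to compound 3 (0.51 log units; beyond the scatter) and takes the number beyond the scatter. The halogen on the aromatic carbon counts as well, since bromo in place of chloro gives a 2.2-fold lower number from compound 1 to compound 3 (0.35 log units; beyond the scatter) on the same phenyl-bearing core. Compound 1 and compound 2 differ in both places, so their close numbers concealed these two separate steps, and nothing measured here explains either one.

Whether phenyl is favoured over propyl with chloro on the aromatic carbon remains open, as the compounds shown offer only one such comparison, made with bromo. From the compounds shown here alone, it is also open how a benzyl or butyl group on the nitrogen, or iodo or methoxy in place of the halogen, would compare.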